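The compounds below may be only part of what the source reports. "The series", "measured", "known", "first", "only" and "open" are said of these compounds alone.

Compound 1 `NS(=O)(=O)CCNc1nonc1/C(=N/O)Nc1ccc(F)c(Br)c1` carries a 2-sulfamoylethyl group on the nitrogen of the shared core, and in an assay on HeLa cells for inhibition of Indoleamine 2,3-dioxygenase 1 (Homo sapiens), read by spectrophotometry, with a stated time of 24 h (a lower number here means that less compound is needed, a higher number that more compound is needed for the effect), compound 1 gives 11 nM. For the measured compounds named here, compound 2 `O=S(=O)(CCNc1nonc1/C(=N/O)Nc1ccc(F)c(Br)c1)N1CCC1` carries azetidin-1-yl in place of amino on the sulfonyl sulfur, and in this assay compound 2 gives 143 nM, the higher of the two numbers measured so far; the step of a 13-fold higher number from compound 1 to compound 2 (1.11 log units; beyond the scatter) is the only measured step. Compound 3 `NS(=O)(=O)CCCNc1nonc1/C(=N/O)Nc1ccc(F)c(Br)c1` has not yet been measured. It differs from compound 2 by sulfamoylmethyl in place of (azetidin-1-yl)sulfonyl on a saturated chain carbon, two bonds along the chain from a nitrogen on an aromatic ring, so the primary sulfonamide of compound 1 returns while the chain becomes 3-sulfamoylpropyl rather than 2-sulfamoylethyl. Going by the values given here, the step from compound 1 to compound 2 bears directly on the first part of this change and was large, so a large move toward a lower number is expected, although no measured pair shows what the longer chain does. Compound 3 is therefore expected to give 20 nM in this assay, between 6 nM and 70 nM, a step of a 7.2-fold lower number from compound 2 to compound 3 (0.85 log units; beyond the scatter).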

Compound 3, half-maximal effective concentration: 15 nM
Compound 3: middle estimate off by 1.3-fold (0.12 log units), on the high side; measured number inside the range.
By their numbers in this assay, from the lowest: compounds 1 and 3 (each within the scatter of the next); then compound 2.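

In this assay, extending the 2-sulfamoylethyl chain to 3-sulfamoylpropyl gives the step of a 1.4-fold higher number from compound 1 to compound 3 (0.13 log units; within the scatter), so the measured numbers do not separate these two chain lengths. The step of a 9.5-fold lower number from compound 2 to compound 3 (0.98 log units; beyond the scatter) shows that a low number can be obtained with the primary sulfonamide on the longer chain too, so a low number is not confined to the 2-sulfamoylethyl chain. No measurement shown here explains why the numbers take these values.

Azetidin-1-yl has been seen only on the shorter chain, so its effect on the 3-sulfamoylpropyl chain remains unknown, and the step from compound 2 cannot be divided between the sulfonamide change and the chain change. Also open, on these data alone, are a still longer chain, such as 4-sulfamoylbutyl, and a carboxylic acid in place of the sulfamoyl group.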